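Replacing the Amino Chain of Compound 3 with an Azetidine

The compounds below may be only part of what the source reports. "The series", "measured", "known", "first", "only" and "open" are said of these compounds alone.

In a functional assay on MCF7 cells (Homo sapiens) for antiproliferative activity, read by CCK-8 assay, with a stated time of 48 h (on this read-out lower numbers stand for stronger inhibition and higher numbers for weaker inhibition), compound 1 `CN(C)C(=O)/C=C/CNCCOc1ccc(Oc2c(-c3ccc(F)cc3)sc3cc(O)ccc23)cc1` gives 13800 nM and compound 3 `O=C(/C=C/CNCCOc1ccc(Oc2c(-c3ccc(F)cc3)sc3cc(O)ccc23)cc1)N1CCC1` gives 7340 nM. These two values sit within the usual scatter of each other, as a 1.9-fold lower number from compound 1 to compound 3 (0.27 log units; within the scatter) shows. Compound 2 `O=C(CCCNCCOc1ccc(Oc2c(-c3ccc(F)cc3)sc3cc(O)ccc23)cc1)N1CCC1` gives > 25000 nM, which is a limit of the assay and not a number. The step of an at least 3.4-fold lower number from compound 2 to compound 3 (0.53 log units; beyond the scatter) is the only clear separation among these compounds.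

Compound 4 `C=C(C)C(=O)N1CC(Oc2ccc(Oc3c(-c4ccc(F)cc4)sc4cc(O)ccc34)cc2)C1` has not yet been measured. In it, on an oxygen on an aromatic ring, 1-((1-methylethenyl)carbonyl)azetidin-3-yl takes the place of 2-((3-((azetidin-1-yl)carbonyl)prop-2-en-1-yl)amino)ethyl (1-((1-methylethenyl)carbonyl)azetidin-3-yl in place of 2-((3-((azetidin-1-yl)carbonyl)prop-2-en-1-yl)amino)ethyl on an oxygen on an aromatic ring). For the measured compounds named here, no measured step replaces this whole group. The two steps to compound 3 change only part of it, so they offer weak guidance, and neither sets a clear direction for so large a change. The expected size of the change is modest, within the scatter: a 1.6-fold higher number from compound 3 to compound 4 (0.21 log units; within the scatter). In this assay the estimate for compound 4 is 12000 nM, expected to lie between 4000 nM and 25000 nM.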

Compound 4, half-maximal inhibitory concentration: > 25000 nM
Compound 4: only a limit was reported (the forecaster's own chance of this, stated with the estimate: 30%); at least 2.0-fold (0.31 log units) between middle value and limit.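

Exchanging the whole amino chain on an oxygen on an aromatic ring for 1-((1-methylethenyl)carbonyl)azetidin-3-yl gives an at least 3.4-fold higher number from compound 3 to compound 4 (0.53 log units; beyond the scatter), so in this assay this is the first change at this position shown to weaken the read-out beyond the scatter. The same exchange gives an at least 1.8-fold higher number from compound 1 to compound 4 (0.25 log units; that floor lies within the scatter), and that comparison alone settles little. The step from compound 2 to compound 4 cannot be read because each compound has only a limit, not a number: the limit of > 25000 nM in this assay, at which 2 of the 4 values shown sit.

The exchange removes the chain amine and the amide at its end and adds the azetidine link in one move, so the data do not show which part matters. As far as these compounds go, whether an acetyl in place of the 1-methylethenyl carbonyl, or a longer chain joining the azetidine to the oxygen, would change the read-out remains open.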